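The source may hold more compounds than are shown below. What is called first, only, known or untested is meant among the compounds shown, and "the series" means these compounds.

Among the measured compounds shown here, compound 1 `O=c1c(-c2nn[nH]n2)c[nH]c2c(Cl)cccc12` is the only compound here with a full number in a functional assay on the whole organism (strain Sprague-Dawley) for inhibition, with Rattus norvegicus as the target; a lower number here means that less compound is needed, a higher number that more compound is needed for the effect: compound 1 gives 0.078 mg/kg. Compound 2 `O=c1c(-c2nn[nH]n2)c[nH]c2c(Cl)c(Cl)ccc12` differs from compound 1 by chloro in place of hydrogen on an aromatic carbon. For compound 2 this assay reports only a limit of the assay, > 0.156 mg/kg. The step of an at least 2.0-fold higher number from compound 1 to compound 2 (0.30 log units; that floor lies within the scatter) is therefore a floor rather than a measured size. That floor is the limit of > 0.156 mg/kg in this assay, at which 1 of the 2 values shown sits. For the measured compounds named here, compound 3 `CC(C)Oc1cccc2c(=O)c(-c3nn[nH]n3)c[nH]c12` is the compound still to be measured, and it differs from compound 1 as follows. isopropoxy in place of chloro on an aromatic carbon No measured step exchanges the chloro of compound 1 for another group; the single measured step adds a second chloro on a different aromatic carbon, so it gives no direct guide to this change. Without such a guide, compound 3 is expected to sit close to compound 1 in this assay, with wide uncertainty, so the expected step is a 1.9-fold higher number from compound 1 to compound 3 (0.28 log units; within the scatter). The estimate for compound 3 is 0.15 mg/kg, with a range from 0.04 mg/kg to 0.6 mg/kg.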

Compound 3, minimum effective dose: 0.078 mg/kg
Estimate against measurement, compound 3: 1.9-fold (0.28 log units) above; the range from low to high includes it.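

The earlier step only added a second chloro on a different aromatic carbon, and its size could not be read as more than a floor, so it said nothing about replacing the chloro that compound 1 already carries. Here that exchange can be read in full, since in this assay the step is no change at the digits printed from compound 1 to compound 3 (within the scatter), which means this aromatic carbon, ortho to a fused ring and meta to a fused ring, can hold either chloro or the larger isopropoxy, which brings more heavy atoms and a hydrogen-bond acceptor, without a difference that stands out from the usual spread of repeat measurements. Nothing measured here accounts for why the two groups read alike.

What the compounds leave open is how far this tolerance goes: whether a smaller methoxy, a longer chain such as butoxy, an amine or a carboxylic acid on the same carbon would also hold the dose, and what plain hydrogen there would give. With only chloro and isopropoxy read at this carbon, neither the size of the group nor its oxygen can be singled out as mattering or not mattering.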